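Swapping Ester for Nitrile on a Thiophene Core

This account rests on a few compounds, and the source may have more. Where it says the series, first, only, none or still open, it means among the compounds named here.

Compound 1 `N#Cc1c(N)sc(C(=O)Nc2ccc(Cl)cc2)c1-c1ccccc1`, compound 2 `CCOC(=O)c1c(N)sc(C(=O)Nc2ccc(Cl)cc2)c1-c1ccccc1` and compound 3 `CCOC(=O)c1c(NC(=O)CC#N)sc(C(=O)Nc2ccccc2)c1-c1ccccc1` were tested in a functional assay on SMMC-7721 cells (Homo sapiens) for inhibition, read by MTT assay; a higher number here means a weaker inhibitor, a lower number a stronger inhibitor. Compound 1 gives 690 nM, compound 2 gives 420 nM and compound 3 gives 530 nM. The change from compound 2 to compound 1 is cyano in place of ethoxycarbonyl on an aromatic carbon and made a step of a 1.6-fold higher number from compound 2 to compound 1 (0.22 log units; within the scatter). The difference between the cores of compound 2 and compound 3 is not broken down here. Compound 4 `N#CCC(=O)Nc1sc(C(=O)Nc2ccccc2)c(-c2ccccc2)c1C#N` has not yet been measured in this assay; it arises from compound 3 by cyano in place of ethoxycarbonyl on an aromatic carbon. This is the same kind of change as before, though the surroundings differ: here the neighbouring ring atom bears a ((cyanomethyl)carbonyl)amino group rather than an amino group. Because of a 1.6-fold higher number from compound 2 to compound 1 (0.22 log units; within the scatter), a comparably small step is expected for compound 4 in this assay, namely a 1.6-fold higher number from compound 3 to compound 4 (0.21 log units; within the scatter). Compound 4 is therefore estimated at 850 nM, between 400 nM and 1800 nM.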

Compound 4, half-maximal inhibitory concentration: 7930 nM
Estimate against measurement, compound 4: 9.3-fold (0.97 log units) below, and the stated range ends below it.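

In this assay, putting cyano in place of ethoxycarbonyl gave a 15-fold higher number from compound 3 to compound 4 (1.17 log units; beyond the scatter), so the change did not carry over at the same size from one core to the other: the same change on two cores in this assay, a 1.6-fold higher number (0.22 log units; within the scatter) from compound 2 to compound 1 and a 15-fold higher number (1.17 log units; beyond the scatter) from compound 3 to compound 4, 9.1-fold (0.96 log units) apart, beyond the scatter of two such steps

The cores differ in more than one place, including the amino group of compound 2 and the ((cyanomethyl)carbonyl)amino group of compound 3, and these compounds cannot show which difference sets the size of the step. A small step on one core is therefore no safe guide to the step on the other, and no cause for the gap can be read here.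

From the compounds shown here alone, it remains open whether an acetylamino group in place of the ((cyanomethyl)carbonyl)amino group would give the large step or the small one. Also open, going by these compounds, is how a carboxylic acid in place of the ethoxycarbonyl would behave on either core.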